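The compounds below may be only part of what the source reports. "The series", "measured", "known", "first", "only" and "open" are said of these compounds alone.

Working notes on the series. Compound 1 `Cc1ccc(Nc2nc3c(=O)[nH]c(C)nc3s2)cc1` gives 20% in an assay on CHO cells for displacement of a labelled ligand from adenosine receptor A1 (Homo sapiens), read by scintillation counting, with a stated time of 120 min, tested at 1 uM; a higher number here means more inhibition at the concentration tested (going by the name of the read-out), a lower number less inhibition. Compound 2 `Cc1nc2sc(Nc3ccc(Cl)cc3)nc2c(=O)[nH]1` gives 33% in this assay; the step of a number 13 percentage points higher from compound 1 to compound 2 (beyond the scatter) goes with the change (chloro in place of methyl on an aromatic carbon). Within the data shown here, compound 3 `CCOc1nc(C)nc2sc(-c3ccc(C)cc3)nc12` has a core that is not the one shared by compounds 1 and 2, and the difference between the two cores is not broken down here. In this assay compound 3 gives 1%. Compound 4 `CCOc1nc(C)nc2sc(-c3ccc(Cl)cc3)nc12` is not yet measured; it differs from compound 3 by chloro in place of methyl on an aromatic carbon, the same change, at the same described place, as that between compounds 1 and 2. On this second core the change is expected to move the number by a number 7 percentage points higher from compound 3 to compound 4 (within the scatter), a step taken as smaller than a number 13 percentage points higher from compound 1 to compound 2 (beyond the scatter) because compound 3 starts from 1% and the cores are not shown to behave alike. Compound 4 is therefore estimated at 8%, expected between 0% and 25%.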

Compound 4, a percentage reported as inhibition, at one concentration (the size of the read-out at that concentration, not a potency): 6%
For compound 4 the middle estimate is 2 percentage points above the measured one; the measured number falls inside the stated range.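

On the second core, chloro in place of methyl goes with a number 5 percentage points higher from compound 3 to compound 4 (within the scatter). Set beside the step on the first core, the change shows no difference between the two cores in this assay: the same change on two cores in this assay, a number 13 percentage points higher (beyond the scatter) from compound 1 to compound 2 and a number 5 percentage points higher (within the scatter) from compound 3 to compound 4, 8 percentage points apart, within the scatter of two such steps. Among these compounds, this is one pair on each core, and it does not show that the change carries over at equal size, only that these two steps cannot be told apart.

Still open, going by these compounds, is whether an amine or a carboxylic acid in place of chloro, on a six-membered aromatic ring of carbon only, would move the number on either core. A direct comparison of the two cores also stays open: no pair shown differs in the core alone.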